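The source may report more compounds than this note shows. Statements on the series, on what has been measured and on what is new or still open speak of the compounds shown alone.

Of the compounds shown here, three of one shared core have been measured in an assay on mitochondria from L6 cells (Rattus norvegicus) for activation, with a stated time of 90 min; on this read-out lower numbers stand for an effect already at smaller amounts and higher numbers for an effect only at larger amounts of compound. Compound 1 `Fc1cccc(Nc2nc3nonc3nc2Nc2ccccc2F)c1` gives 190 nM. Compound 2 `Oc1nc2nonc2nc1Nc1ccccc1F` gives 12500 nM, and compound 3 `Oc1nc2nonc2nc1Nc1ccc(OCC(F)(F)F)c(F)c1` gives 10400 nM. Among these three numbers compound 2 stands highest, although its value and that of compound 3 lie within the usual scatter of each other, so no order between those two can be read. Within the data shown here, the only single-place step known is a 66-fold higher number from compound 1 to compound 2 (1.82 log units; beyond the scatter), and it concerns the replacement of a whole aromatic amine by a hydroxy group, not the ring that is changed here.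

Compound 4 `CCCCCc1ccc(Nc2nc3nonc3nc2O)c(F)c1` is not yet measured. Compared with compound 2 it carries pentyl in place of hydrogen on an aromatic carbon. Among the measured compounds shown here, no measured step touches this kind of change. For the measured compounds named here, the pair compound 2 and compound 3 shows only that adding groups to the same ring left the number within the scatter. On that thin basis a step of at most modest size is expected, with a slight lean toward a lower number for compound 4, a 2.5-fold lower number from compound 2 to compound 4 (0.40 log units; beyond the scatter). In this assay compound 4 is therefore estimated at 5000 nM, with a range from 1200 nM to 20000 nM.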

Compound 4, half-maximal effective concentration: 1500 nM
Compound 4: the middle estimate sits 3.3-fold (0.52 log units) above what was measured; low and high end bracket the measured number.
By their numbers in this assay, from the lowest: compound 1; then compound 4; then compounds 3 and 2 (each within the scatter of the next).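

Putting pentyl in place of hydrogen on an aromatic carbon, meta to a fluoro group and para to a large group, gives an 8.3-fold lower number from compound 2 to compound 4 (0.92 log units; beyond the scatter) in this assay. Among these compounds, this is the first single-place step measured on this ring rather than on the other side of the shared core, and it shows that the position is not indifferent: the number moves beyond the usual scatter when a purely carbon chain with no ring, no hydrogen-bond donors and no hydrogen-bond acceptors enters there. Nothing measured here accounts for why this change lowers the number, so the step stands as an observation and not as an explanation.

The single chain cannot tell whether the effect depends on length, since neither a shorter chain such as methyl nor a longer chain such as octyl appears at this place, and neither does a group of a different kind such as an amine or a carboxylic acid. As far as these compounds go, it also remains open whether pentyl would have a similar effect in compound 1, which carries (3-fluorophenyl)amino where compound 4 carries hydroxy.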